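A few compounds are considered here, and "the series" means these few. Any claim that something is new, unique, unknown or untested is made for them only; others in the source may bear on it.

Measured in a functional assay on KYSE-450 cells (Homo sapiens) for inhibition, read by MTT assay, with a stated time of 48 h; on this read-out higher numbers stand for weaker inhibition and lower numbers for stronger inhibition:
- compound 1 `COc1ccc(CN(C(=O)C=C(C)C)c2cc(OC)c(OC)c(OC)c2)cc1O`: 280 nM
- compound 2 `CC/C=C/C(=O)N(Cc1ccc(OC)c(O)c1)c1cc(OC)c(OC)c(OC)c1`: 72 nM

Among the measured compounds shown here, compound 2, at 72 nM, has the lowest of the two numbers so far. Compound 3 `COc1ccc(CN(C(=O)CO)c2cc(OC)c(OC)c(OC)c2)cc1O` carries hydroxymethyl in place of but-1-en-1-yl on a carbonyl carbon.

For the measured compounds named here, only one measured step bears on this place: a 3.9-fold lower number from compound 1 to compound 2 (0.59 log units; beyond the scatter). That modest step, with but-1-en-1-yl in place of 2-methylprop-1-en-1-yl, shows that the number in this assay responds to the group on this carbonyl carbon. Going by the values given here, no measured compound carries hydroxymethyl, so the size of the next step rests on thin evidence and the range stays wide. A move to a higher number is expected, somewhat larger than the measured step. The expected change is a 3.9-fold higher number from compound 2 to compound 3 (0.59 log units; beyond the scatter). For compound 3 the estimate is 280 nM, with an expected range from 50 nM to 1500 nM.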

Compound 3, half-maximal inhibitory concentration: 370 nM
Beside the measured number, compound 3's estimate is 1.3-fold (0.12 log units) below it; measured number inside the range.
By their numbers in this assay, from the lowest: compound 2; then compounds 1 and 3 (each within the scatter of the next).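

In this assay, the carbonyl carbon now gives a second step beyond the scatter, with hydroxymethyl in place of but-1-en-1-yl: a 5.1-fold higher number from compound 2 to compound 3 (0.71 log units; beyond the scatter). With hydroxymethyl in place of 2-methylprop-1-en-1-yl, the reading is a 1.3-fold higher number from compound 1 to compound 3 (0.12 log units; within the scatter), so of the three groups only but-1-en-1-yl stands apart, and a double bond outside aromatic rings does not by itself mark the lower number, as compound 1 also carries one. Nothing measured here explains the difference between these groups.

Going by these compounds, it remains open whether a saturated butyl chain on this carbonyl carbon would keep the number of compound 2 or fall in with compound 1 and compound 3. An aminomethyl group or a carboxylic acid at this place would test how far the position tolerates other groups.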